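This account rests on a few compounds, and the source may have more. Where it says the series, first, only, none or still open, it means among the compounds named here.

Three dihydropyridines have been measured in a functional assay on HEK293 cells for antagonist activity at Voltage-dependent L-type calcium channel subunit alpha-1C (Oryctolagus cuniculus), read by FLIPR; a lower number here means a stronger inhibitor, a higher number a weaker inhibitor. Compound 1 `CCOC(=O)C1=C(C)NC(COC)=C(C(=O)OC)C1c1cccc([N+](=O)[O-])c1` gives 14 nM. Compound 2 `C#CCCOC(=O)C1=C(C)NC(C)=C(C(=O)OC)C1c1cccc([N+](=O)[O-])c1` gives 31 nM. Compound 3 `CCCCCOC(=O)C1=C(C)NC(C)=C(C(=O)OCC)C1c1cccc([N+](=O)[O-])c1` gives 49 nM. Compound 2 stands second highest of these three numbers: its gap to compound 3 lies within the scatter, so no order between the two can be claimed, while compound 1 sits beyond the scatter below it and is the stronger inhibitor of the pair.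

Compound 4 `COC(=O)C1=C(C)NC(C)=C(C(=O)OCCCCc2ccccc2)C1c1cccc([N+](=O)[O-])c1` has not yet been measured. It differs from compound 2 at one ester chain only: phenethyl in place of ethynyl on a saturated chain carbon, two bonds along the chain from an oxygen next to a carbonyl group. Going by the values given here, the measured compounds do not show any step of this kind, and the only change in an ester chain among them, from the shorter chains of compound 2 to the longer pentyl chain of compound 3, is within the scatter. For compound 4 the step of a 1.0-fold lower number from compound 2 to compound 4 (0.01 log units; within the scatter) is therefore expected to stay within the usual scatter, with no clear direction. Compound 4 is estimated at 30 nM, within a range from 10 nM to 90 nM.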

Compound 4, half-maximal inhibitory concentration: 10 nM
Estimate against measurement, compound 4: 3.0-fold (0.48 log units) above; measured number inside the range.
By their numbers in this assay, from the lowest: compounds 4 and 1 (each within the scatter of the next); then compounds 2 and 3 (each within the scatter of the next).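

In this assay, going by these compounds alone, this ester chain gives the first single-place change that moves the number beyond the scatter: going from but-3-yn-1-yl to 4-phenylbutyl gives a 3.1-fold lower number from compound 2 to compound 4 (0.49 log units; beyond the scatter) as a modest gain in inhibition. The position, on a saturated chain carbon, two bonds along the chain from an oxygen next to a carbonyl group, therefore tolerates phenethyl, with 8 heavy atoms and an aromatic ring against 2 heavy atoms for ethynyl, and the compound gets stronger rather than weaker. No measurement shown here explains this step.

Still open, as far as these compounds go, is whether the aromatic ring or the chain length matters more, which an octyl chain or a 4-cyclohexylbutyl chain could separate. A single step also cannot show how much further the chain can grow, as with 6-phenylhexyl, or whether a chain ending in an amine is accepted.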